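The source may report more compounds than this note shows. Statements on the series, on what has been measured and on what is new or still open speak of the compounds shown alone.

Working notes on the series. In an assay on CHO cells for displacement of a labelled ligand from prostaglandin E2 receptor EP3 subtype (Homo sapiens), read by radioligand binding (on this read-out higher numbers stand for weaker inhibition and lower numbers for stronger inhibition), compound 1 `CCn1ncc2c(F)cc(-c3ccc(C(CC)(CC)c4nnc[nH]4)c(=O)[nH]3)cc21` gives 17 nM, and compound 2 `CCn1ncc2c(F)cc(-c3ccc(C(CC)(CC)c4nnc(C)[nH]4)c(=O)[nH]3)cc21` gives 34 nM. Compound 2 has the highest of the two numbers in this assay, its nearest neighbour being compound 1; that step, a 2.0-fold higher number from compound 1 to compound 2 (0.30 log units; within the scatter), lies within the scatter, so no order between the two is claimed.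

Compound 3 `CCn1ncc2c(F)cc(-c3ccc(C(CC)(CC)c4nncn4C)c(=O)[nH]3)cc21` is not yet measured. It differs from compound 2 by 4-methyl-4H-1,2,4-triazol-3-yl in place of 5-methyl-4H-1,2,4-triazol-3-yl on a saturated chain carbon bound to an aromatic carbon and two saturated chain carbons. For the measured compounds named here, the only measured step, a 2.0-fold higher number from compound 1 to compound 2 (0.30 log units; within the scatter), concerns a methyl added on an aromatic carbon, not a methyl moved from carbon to nitrogen, so it bears on this change only as a sign that methyl substitution on the triazole has so far stayed within the scatter. Going by the values given here, the change also removes a hydrogen-bond donor, for which no measured step exists. The step expected in this assay is a 1.8-fold higher number from compound 2 to compound 3 (0.25 log units; within the scatter), a slight weakening at most. For compound 3 the estimate in this assay is 60 nM, with a range from 15 nM to 250 nM.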

Compound 3, inhibition constant: 54 nM
Estimate against measurement, compound 3: 1.1-fold (0.05 log units) above; the range from low to high includes it.
By their numbers in this assay, from the lowest: compounds 1, 2 and 3 (each within the scatter of the next, the first and the last beyond it).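

In this assay, shifting the methyl from ring carbon to ring nitrogen gives a 1.6-fold higher number from compound 2 to compound 3 (0.20 log units; within the scatter), so 5-methyl-4H-1,2,4-triazol-3-yl and 4-methyl-4H-1,2,4-triazol-3-yl are not told apart here, even though the entering group has no hydrogen-bond donor. Methyl in place of hydrogen on an aromatic nitrogen gives a 3.2-fold higher number from compound 1 to compound 3 (0.50 log units; beyond the scatter), the first step on this triazole beyond the scatter, though only modest in size, whereas methyl on the aromatic carbon gave a 2.0-fold higher number from compound 1 to compound 2 (0.30 log units; within the scatter). No measurement is available that accounts for these steps.

Open, going by these compounds, is whether an ethyl group or a longer chain on the same ring nitrogen would extend the step, and how an amine on the ring carbon would read. Also open, on these data alone, is whether the step from hydrogen to methyl on nitrogen holds when other parts of the shared core change.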